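The compounds below may be only part of what the source reports. "The series", "measured", "known", "first", "only" and "open" are said of these compounds alone.

Working notes on the series, read in a functional assay on MCF7 cells (Homo sapiens) for cytotoxicity, read by MTT assay, with a stated time of 72 h; a higher number here means a weaker inhibitor, a lower number a stronger inhibitor. Compound 1 (`COc1cccc(/C=C2\CCC/C(=C\c3ccc(Br)cc3)C2=O)c1OC`) gives 13800 nM and compound 2 (`COc1ccc(/C=C2\CCC/C(=C\c3cccc(Cl)c3)C2=O)cc1OC`) gives 6000 nM. Compound 2 therefore holds the lower of the two numbers, and the gap between them lies beyond the usual scatter. Compound 3 (`COc1ccccc1/C=C1\CCC/C(=C\c2ccc(OC)c(OC)c2)C1=O`) has not yet been measured. It differs from compound 2 in one place: 2-methoxyphenyl in place of 3-chlorophenyl on a double-bonded chain carbon bound to a double-bonded ring carbon, with 2-methoxyphenyl in place of 3-chlorophenyl on a double-bonded chain carbon bound to a double-bonded ring carbon. Among the compounds with values here, no measured pair isolates this change, so the expectation rests on little. Within the data shown here, the only other number available is that of compound 1 at 13800 nM, and a small upward move towards it, probably within the scatter, is expected. The expected change is a 1.3-fold higher number from compound 2 to compound 3 (0.12 log units; within the scatter). Compound 3 is estimated at 8000 nM, with an expected range of 3000 nM to 20000 nM.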

Compound 3, half-maximal inhibitory concentration: 8000 nM
Compound 3: middle estimate and measured number agree at the digits printed; low and high end bracket the measured number.
By their numbers in this assay, from the lowest: compounds 2, 3 and 1 (each within the scatter of the next, the first and the last beyond it).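

In this assay, within the data shown here, this is the first pair to isolate a change at this position: 2-methoxyphenyl in place of 3-chlorophenyl on a double-bonded chain carbon bound to a double-bonded ring carbon gives a 1.3-fold higher number from compound 2 to compound 3 (0.12 log units; within the scatter). In this pair, the chlorine of the 3-chlorophenyl group is therefore not needed to keep the number within the scatter, and the 2-methoxyphenyl group, with its added hydrogen-bond acceptor, serves equally well. No independent data bear on why these two groups read alike.

The pair changes both the atoms on the phenyl ring and where they sit, so it cannot separate those two effects. Going by these compounds, whether an amine or a carboxylic acid on the phenyl ring at this place would leave the number within the scatter remains open.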